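Trading isopropyl for methyl in a breast-cancer cell assay

The source may hold more compounds than are shown below. What is called first, only, known or untested is meant among the compounds shown, and "the series" means these compounds.

Going by the values given here, compound 2 `CC(C)c1ccc(-c2nc(SCc3cn(CC(=O)NC(=O)Nc4ccccn4)nn3)nc(Nc3cccc(C(F)(F)F)c3)c2C#N)cc1` is the one member of this small set with a definite number in a functional assay on MCF7 cells (Homo sapiens) for inhibition, read by MTT assay, with a stated time of 72 h; a lower number here means a stronger inhibitor, a higher number a weaker inhibitor: compound 2 gives 8620 nM. Compound 1 `CC(C)c1ccc(-c2nc(SCc3cn(CC(=O)NC(=O)Nc4ccccn4)nn3)nc(Nc3ccc(F)cc3)c2C#N)cc1` reaches only a limit of the assay, giving > 64000 nM. Compound 3 `Cc1cccc(Nc2nc(SCc3cn(CC(=O)NC(=O)Nc4ccccn4)nn3)nc(-c3ccc(C(C)C)cc3)c2C#N)c1` likewise stops at a limit, giving > 64000 nM. The measured steps, an at least 7.4-fold lower number from compound 1 to compound 2 (0.87 log units; beyond the scatter), an at least 7.4-fold higher number from compound 2 to compound 3 (0.87 log units; beyond the scatter) and a step that the two limits leave unreadable from compound 1 to compound 3, all alter the group on the nitrogen; none touches the isopropyl. Compound 4 `Cc1ccc(-c2nc(SCc3cn(CC(=O)NC(=O)Nc4ccccn4)nn3)nc(Nc3cccc(C(F)(F)F)c3)c2C#N)cc1` differs from compound 2 by methyl in place of isopropyl on an aromatic carbon. Among the compounds with values here, no measured step bears on this change, so the expectation rests on compound 2 alone, and a step within the usual scatter is expected, a 1.2-fold higher number from compound 2 to compound 4 (0.06 log units; within the scatter). Compound 4 is therefore estimated at 10000 nM, between 3000 nM and 40000 nM.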

Compound 4, half-maximal inhibitory concentration: 6120 nM
For compound 4 the middle estimate is 1.6-fold (0.21 log units) above the measured one, and the stated range covers the measured number.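

Methyl in place of isopropyl gives a 1.4-fold lower number from compound 2 to compound 4 (0.15 log units; within the scatter) in this assay, so compounds 2 and 4 cannot be told apart at this position. The earlier steps shown here changed only the group on the nitrogen, whereas this one shows that, with 3-(trifluoromethyl)phenyl kept there, the definite number survives the change from 4-isopropylphenyl to 4-methylphenyl. Nothing shown here gives a cause for this result.

From the compounds shown here alone, whether a longer chain, an amine or a carboxylic acid at this position would leave the number as it stands remains open. So does whether methyl would behave the same way with a different group on the nitrogen.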